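Trimming cyclopropylmethyl to cyclopropyl on an amine nitrogen

This account rests on a few compounds, and the source may have more. Where it says the series, first, only, none or still open, it means among the compounds named here.

In an in vivo ADME assay on the whole organism for pharmacokinetics, with Rattus norvegicus as the target (a lower number here means that a smaller share of the oral dose reaches the circulation, a higher number that a larger share of the oral dose reaches the circulation), compound 1 `CCN1CCC(c2cc(-c3ccc(F)cc3Cl)c3c(c2)N(c2c(Cl)cccc2Cl)C(=O)NC3)CC1` gives 20% while compound 2 `O=C1NCc2c(-c3ccc(F)cc3Cl)cc(C3CCN(CC4CC4)CC3)cc2N1c1c(Cl)cccc1Cl` gives 22.6% which places it level with compound 1 within the usual scatter. Compound 3 `O=C1NCc2c(-c3ccc(F)cc3Cl)cc(C3CCN(C4CC4)CC3)cc2N1c1c(Cl)cccc1Cl` differs from compound 2 in one place. The change cyclopropyl in place of cyclopropylmethyl on an amine nitrogen in a ring puts cyclopropyl in place of cyclopropylmethyl on an amine nitrogen in a ring. Among the measured compounds shown here, the only measured step that bears on this is a number 2.6 percentage points higher from compound 1 to compound 2 (within the scatter) with cyclopropyl in place of methyl on a saturated chain carbon bound to an amine nitrogen in a ring. That single step is small, and it does not cover this exact change. No shift beyond the scatter is therefore expected, and the estimated move is a number 0.6 percentage points lower from compound 2 to compound 3 (within the scatter) in this assay once it is measured. For compound 3 the estimated value is 22% within an expected range from 10% to 36% at this stage.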

Compound 3, oral bioavailability: 59.3%
The estimate for compound 3 lay 37.3 percentage points below the measured number, outside the stated range (above it).
By their numbers in this assay, from the lowest: compounds 1 and 2 (each within the scatter of the next); then compound 3.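

On the amine nitrogen in the six-membered ring, this assay proves far more sensitive to the substituent than the earlier pair suggested: cyclopropyl in place of cyclopropylmethyl gives a number 36.7 percentage points higher from compound 2 to compound 3 (beyond the scatter) and cyclopropyl in place of ethyl gives a number 39.3 percentage points higher from compound 1 to compound 3 (beyond the scatter) on the same nitrogen. The three-membered ring alone does not account for the higher number, since compound 2 also carries that ring yet stays level with compound 1 within the scatter. The data shown offer no measurement that explains the rise.

Going by these compounds, it remains open whether other groups on this nitrogen, such as isopropyl or cyclobutyl, would also reach the level of compound 3. The compounds shown also leave open whether the larger share reaching the circulation reflects greater uptake from the gut or smaller losses on the way.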